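A few compounds are considered here, and "the series" means these few. Any claim that something is new, unique, unknown or untested is made for them only; others in the source may bear on it.

Compound 3, `O=C(NC[C@@H]1C[C@@H]2C=C[C@@H]1C2)NS(=O)(=O)N1CCC(CCNC(=O)c2cccc3cccnc23)CC1`, stands highest of the three compounds measured in a functional assay on the whole organism (blood) with Rattus norvegicus as the target, with stated times of 24 h and 1 h, at a dose of 5 mg/kg by the intraperitoneal route (a lower number here means a weaker effect, a higher number a stronger effect of the compound at the dose given), where compound 3 gives 34%. Compound 2, `O=C(NC[C@@H]1C[C@@H]2C=C[C@@H]1C2)NS(=O)(=O)N1CCC(CCNC(=O)c2ccc3ccccc3n2)CC1`, gives 21% in this assay, and compound 1, `COc1ccc(C(=O)NCCC2CCN(S(=O)(=O)NC(=O)NC[C@@H]3C[C@@H]4C=C[C@@H]3C4)CC2)cn1`, gives 11%. The two steps leading up to compound 3 are both beyond the scatter: a number 23 percentage points higher from compound 1 to compound 3 (beyond the scatter) and a number 13 percentage points higher from compound 2 to compound 3 (beyond the scatter), whereas a number 10 percentage points higher from compound 1 to compound 2 (within the scatter).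

Compound 4, `O=C(NC[C@@H]1C[C@@H]2C=C[C@@H]1C2)NS(=O)(=O)N1CCC(CCNC(=O)c2cccc3c2OCCO3)CC1`, has not yet been measured in this assay. It differs from compound 3 in one place: 2,3-dihydro-1,4-benzodioxin-5-yl in place of quinolin-8-yl on a carbonyl carbon. Among the compounds with values here, none of the measured steps makes this particular exchange, but all three swap one ring group for another on the same carbonyl carbon, and the sizes of those steps ranged from within the scatter to modest. A change of this kind is therefore expected to move the number by no more than a modest amount, and since compound 3 holds the top position, the estimate for a number 12 percentage points lower from compound 3 to compound 4 (beyond the scatter) is a modest fall or none beyond the scatter. Compound 4 is accordingly expected to give about 22% in this assay, with a range from 8% to 38%.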

Compound 4, a percentage reported as activity, at one dose (the size of the read-out at that dose, not a potency): 11%
Compound 4: middle estimate off by 11 percentage points, on the high side; the measured number falls inside the stated range.
By their numbers in this assay, from the lowest: compounds 1, 4 and 2 (each within the scatter of the next); then compound 3.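

In this assay, the exchange of quinolin-8-yl for 2,3-dihydro-1,4-benzodioxin-5-yl, two groups with the same heavy-atom count, gives a number 23 percentage points lower from compound 3 to compound 4 (beyond the scatter), so this place on the carbonyl carbon separates two fused ring groups that are not isomers of one another, which the two quinolines alone could not show. The other steps, a number 10 percentage points lower from compound 2 to compound 4 (within the scatter) and no change at the digits printed from compound 1 to compound 4 (within the scatter), are both within the scatter, leaving compound 3 as the only one of the four set apart from all the others. Nothing measured here explains that gap.

Going by these compounds, what a naphthalen-1-yl group on this carbonyl carbon would give, with carbon in place of the ring nitrogen of quinolin-8-yl, stays open. So does the effect of an amine or a carboxylic acid on that ring, and whether any such group would surpass compound 3, at 34%.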